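The source may report more compounds than this note shows. Statements on the series, on what has been measured and on what is new or still open speak of the compounds shown alone.

Measured so far in a functional assay on K562 cells (Homo sapiens) for inhibition, read by trypan blue exclusion, with a stated time of 72 h; a lower number here means a stronger inhibitor, a higher number a weaker inhibitor:

Compound 1, `Cn1c(=O)c(S(=O)(=O)c2ccc(F)cc2[N+](=O)[O-])cc2cnc(Nc3ccc4[nH]ccc4c3)nc21`: 900 nM
Compound 2, `Cc1ccc(S(=O)(=O)c2cc3cnc(Nc4cccc5cccnc45)nc3n(C)c2=O)cc1`: 10000 nM
Compound 3, `Cn1c(=O)c(S(=O)(=O)c2ccc(F)cc2)cc2cnc(Nc3cnc4[nH]ccc4c3)nc21`: 750 nM

Compound 2 stands at the highest number of the three, beyond the scatter from both compound 1 and compound 3, so on these numbers it is the weakest inhibitor in this assay. Compound 1 and compound 3 lie within the scatter of each other.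

The next compound is compound 4, `COc1ccc(Nc2ncc3cc(S(=O)(=O)c4ccc(C)cc4)c(=O)n(C)c3n2)cc1`. It differs from compound 2 in one place: 4-methoxyphenyl in place of quinolin-8-yl on a nitrogen on an aromatic ring.

Within the data shown here, no pair of measured compounds shares exactly this change, so the size of the step is not fixed by the data. Compound 1 and compound 3 show that a different group on the same nitrogen, together with other changes, goes with a much lower number than compound 2, but they are not single steps from compound 2 and carry no information on 4-methoxyphenyl itself. The expectation for the step from compound 2 to compound 4 in this assay is a modest fall in the number, a 3.3-fold lower number from compound 2 to compound 4 (0.52 log units; beyond the scatter), with a wide range either side.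

Compound 4 is estimated at 3000 nM, expected to fall between 800 nM and 10000 nM.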

Compound 4, half-maximal inhibitory concentration: 75000 nM
Compound 4: middle estimate off by 25-fold (1.40 log units), on the low side; the whole stated range lies below it.
By their numbers in this assay, from the lowest: compounds 3 and 1 (each within the scatter of the next); then compound 2; then compound 4.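

Among these compounds, on the nitrogen on an aromatic ring, 4-methoxyphenyl in place of quinolin-8-yl gives a 7.5-fold higher number from compound 2 to compound 4 (0.88 log units; beyond the scatter) in this assay, the first single-place reading. With the rest of the compound held fixed, the group on this nitrogen alone moves the number beyond the scatter, and quinolin-8-yl is the better of these two groups in this cell assay. Nothing measured here accounts for the size or direction of this step.

Among the compounds shown here, compound 1 and compound 3 differ from compound 2 and compound 4 in more than one place, so no steps to them can be read. As far as these compounds go, it remains open whether an unsubstituted phenyl, or a phenyl carrying an amine or a carboxylic acid instead of methoxy, would stand nearer compound 2 or compound 4.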